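The source may report more compounds than this note shows. Statements on the series, on what has been measured and on what is new or still open speak of the compounds shown alone.

Working notes on a small set of pyrazine-carboxylate esters of cinnamate-type phenols, assessed in a functional assay on EA.hy 926 cells (Homo sapiens) for cytotoxicity, read by MTT assay, with stated times of 24 h and 12 h; a higher number here means that more compound is needed for the effect, a lower number that less compound is needed.

Compound 1, `COc1cc(/C=C/C(=O)O)ccc1OC(=O)c1nc(C)c(C)nc1C`, gives 69400 nM in this assay. Compound 2, `COc1cc(/C=C/C(=O)O)cc(OC)c1OC(=O)c1nc(C)c(C)nc1C`, gives 34700 nM. The difference between them is hydrogen in place of methoxy on an aromatic carbon, and the step is a 2.0-fold higher number from compound 2 to compound 1 (0.30 log units; within the scatter). Compound 3, `CCOC(=O)/C=C/c1cc(OC)ccc1OC(=O)c1nc(C)c(C)nc1C`, gives 105000 nM; its number and that of compound 1 sit within the usual scatter, while its number and that of compound 2 lie apart beyond it. The difference between the cores of compound 3 and compound 2 is not broken down here.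

Compound 4, `CCOC(=O)/C=C/c1ccccc1OC(=O)c1nc(C)c(C)nc1C`, is not yet measured. It differs from compound 3 by hydrogen in place of methoxy on an aromatic carbon. This is the same kind of change as from compound 2 to compound 1, though the surroundings differ: in compound 2 the leaving group sits ortho to a large group, meta to a 2-carboxyethenyl group and meta to a methoxy group, whereas in compound 3 it sits meta to a 2-(ethoxycarbonyl)ethenyl group and para to a large group. Given that the earlier step was a 2.0-fold higher number from compound 2 to compound 1 (0.30 log units; within the scatter), a small step is expected here as well, a 1.3-fold higher number from compound 3 to compound 4 (0.12 log units; within the scatter). For compound 4 the estimate is 140000 nM, likely between 70000 nM and 300000 nM.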

Compound 4, half-maximal effective concentration: 108000 nM
Compound 4: the middle estimate sits 1.3-fold (0.11 log units) above what was measured; low and high end bracket the measured number.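

In this assay hydrogen in place of methoxy gives a 1.0-fold higher number from compound 3 to compound 4 (0.01 log units; within the scatter) and does not separate the two compounds. Two pairs on two cores are a narrow base: each step lies within the scatter, which does not show that the methoxy group has any effect on the number on either core, and it does not show how the change would behave on a core outside this set. What can be said is limited to these two pairs, where the step from one core does not differ from the step on the other: the same change on two cores in this assay, a 2.0-fold higher number (0.30 log units; within the scatter) from compound 2 to compound 1 and a 1.0-fold higher number (0.01 log units; within the scatter) from compound 3 to compound 4, 1.9-fold (0.29 log units) apart, within the scatter of two such steps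

The compounds shown leave open whether another group on this aromatic carbon, such as an amine, a hydroxyl or a longer alkoxy chain, would give a step beyond the scatter. They also leave open how a carboxylic acid and an ethyl ester compare when the two cores differ in that one place only.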